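A Methoxy-for-Chloro Swap Among Compounds at the Limit

The compounds below may be only part of what the source reports. "The series", "measured", "known", "first", "only" and "open" are said of these compounds alone.

Compound 3 `Cc1ccc(Nc2nc(C)c(C(=O)/C=C/c3ccccc3Cl)s2)cc1` was tested in a functional assay on Bel-7402 cells (Homo sapiens) for cytotoxicity, read by MTT assay; a higher number here means a weaker inhibitor, a lower number a stronger inhibitor. In this assay compound 3 gives > 25000 nM, which is a limit of the assay and not a number. Compound 1 `COc1cccc(/C=C/C(=O)c2sc(Nc3cccc(C)c3)nc2C)c1` likewise gives only a limit in this assay, > 25000 nM. Compound 2 `COc1cccc(/C=C/C(=O)c2sc(Nc3ccccc3C)nc2C)c1` also gives only a limit in this assay, > 25000 nM. Among the measured compounds shown here, all three measured values thus sit together, as the limit of > 25000 nM in this assay, at which 3 of the 3 values shown sit, records, and the single measured step, a step that the two limits leave unreadable from compound 1 to compound 2, is one that the two limits leave unreadable.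

Compound 4 `COc1cccc(/C=C/C(=O)c2sc(Nc3ccc(C)cc3)nc2C)c1` differs from compound 3 by 3-methoxyphenyl in place of 2-chlorophenyl on a double-bonded chain carbon bound to a double-bonded chain carbon. The entering 3-methoxyphenyl is the same group carried by compound 1 and compound 2, while the substituent on the nitrogen is carried over from compound 3 unchanged. For the measured compounds named here, no measured step bears on this change in readable size. With nothing pointing away from the limit, compound 4 is expected to remain there, the expected step being a step that the limit leaves unreadable from compound 3 to compound 4. Compound 4 is accordingly estimated at 30000 nM, within 10000 nM to 100000 nM, most likely reported again only as a limit.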

Compound 4, half-maximal inhibitory concentration: > 25000 nM
Compound 4: a limit, no number; the forecaster's own chance of this, stated with the estimate: 75%; the middle value is on the limit's open side.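

In this assay compound 4 gives > 25000 nM, which is a limit and not a number. Among the compounds shown here, no step among compound 1, compound 2, compound 3 and compound 4 can be read: the limit of > 25000 nM in this assay, at which 4 of the 4 values shown sit. The compounds shown leave open whether swapping 2-chlorophenyl for 3-methoxyphenyl, or moving the methyl group on the methylphenyl, changes activity at all.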